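The source may report more compounds than this note shows. Statements on the series, on what has been measured and on what is new or still open speak of the compounds shown alone.

Measured so far in an ADME assay on HepG2 2.2.15 cells (Homo sapiens) for cytotoxicity; a higher number here means that more compound is tolerated, a lower number that less compound is tolerated:
- compound 1, `CC(=O)OCCc1c(-c2ccccc2Cl)c2cc(Cl)ccc2[nH]c1=O`: 27000 nM
- compound 2, `CC(C)C(=O)OCCc1c(-c2ccccc2Cl)c2cc(Cl)ccc2[nH]c1=O`: 62000 nM
- compound 3, `O=C(CCC1CCCCC1)OCCc1c(-c2ccccc2Cl)c2cc(Cl)ccc2[nH]c1=O`: 160000 nM

Compound 2 sits second highest of the three numbers in this assay; compound 1 is the nearest, with a 2.3-fold higher number from compound 1 to compound 2 (0.36 log units; beyond the scatter) running up to it, and compound 3 lies furthest, with a 2.6-fold higher number from compound 2 to compound 3 (0.41 log units; beyond the scatter) beyond it. The step of a 5.9-fold higher number from compound 1 to compound 3 (0.77 log units; beyond the scatter) spans the whole measured range.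

Compound 4, `O=C(CN1C(=O)c2ccccc2C1=O)OCCc1c(-c2ccccc2Cl)c2cc(Cl)ccc2[nH]c1=O`, is not yet measured in this assay. It differs from compound 2 by a group of 12 heavy atoms (9 carbon, 1 nitrogen, 2 oxygen; one five-membered non-aromatic ring with 1 hetero atom, one six-membered aromatic ring of carbon only) in place of a group of 3 heavy atoms (3 carbon; no ring), on a carbonyl carbon. All three measured steps bear on the question, since each of them also enlarges the group on that carbonyl carbon, and each gave a modest rise beyond the scatter. The group entering in compound 4 is, however, of a different kind from the isopropyl and cyclohexyl-bearing chains that gave those rises, so the pattern is carried over only loosely. A modest rise, or a step within the scatter, is expected from compound 2 to compound 4, a 1.5-fold higher number from compound 2 to compound 4 (0.16 log units; within the scatter). The estimate for compound 4 in this assay is 90000 nM, within 35000 nM to 250000 nM.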

Compound 4, half-maximal cytotoxic concentration: 960000 nM
Estimate against measurement, compound 4: 11-fold (1.03 log units) below, and the stated range ends below it.
By their numbers in this assay, from the lowest: compound 1; then compound 2; then compound 3; then compound 4.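

In this assay, the group on the carbonyl carbon can move the number much further than the alkyl groups suggested (  a 15-fold higher number from compound 2 to compound 4 (1.19 log units; beyond the scatter)) and (a 36-fold higher number from compound 1 to compound 4 (1.55 log units; beyond the scatter)), and compound 3 is no ceiling at this position (a 6.0-fold higher number from compound 3 to compound 4 (0.78 log units; beyond the scatter)). The order of all four compounds follows the heavy-atom count of this group, with none going against it, but the group in compound 4 is also the only one holding nitrogen and oxygen, so size and kind of group cannot be separated here. Nothing available explains the size of this rise.

Still open, on these data alone, is whether a plain benzyl group or an open-chain amide on the same carbon would reach a similar number. As far as these compounds go, an amine or a carboxylic acid there also remains untested in these compounds.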